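Taking the methoxy off a poorly soluble compound

The source may hold more compounds than are shown below. What is called first, only, known or untested is meant among the compounds shown, and "the series" means these compounds.

In a physicochemical assay for solubility, using the shake flask method, in phosphate buffer, with a stated time of 24 h, at pH 7.4 (on this read-out higher numbers stand for higher solubility and lower numbers for lower solubility), compound 1 `COc1cccc(C(C)Sc2nc3c(cnn3C)c(=O)n2-c2ccccc2)c1` gives < 2000 nM, which is a limit of the assay and not a number. Two relatives give real numbers: compound 2 `O=c1c2cncn2nc(SCc2cccc(F)c2)n1-c1ccccc1` shows 47000 nM and compound 3 `Cn1ncc2c(=O)n(-c3ccccc3)c(CNc3cccc(F)c3)nc21` shows 64000 nM. Among the measured compounds shown here, no single change links either of them to compound 1, so no measured step serves as a guide here.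

Compound 4 `CC(Sc1nc2c(cnn2C)c(=O)n1-c1ccccc1)c1ccccc1` keeps the core of compound 1 and differs in one place: hydrogen in place of methoxy on an aromatic carbon. In words, hydrogen stands in place of methoxy on an aromatic carbon, so 3-methoxyphenyl becomes phenyl.

With so little to go on, only a small upward move is expected, and the reading could again stop at the limit of this assay. This expectation stays anchored on compound 1, with its limit of < 2000 nM. The expected step is an at least 1.2-fold higher number from compound 1 to compound 4 (0.09 log units; that floor lies within the scatter). For compound 4 the estimated solubility is 2500 nM, with an expected range from 700 nM to 10000 nM.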

Compound 4, solubility: 8000 nM
Beside the measured number, compound 4's estimate is 3.2-fold (0.51 log units) below it; the measured number falls inside the stated range.
By their numbers in this assay, from the lowest: compound 4; then compounds 2 and 3 (each within the scatter of the next). At a limit, below all of these: compound 1.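

In this assay, among the compounds shown here, hydrogen in place of methoxy on this aromatic carbon gives an at least 4.0-fold higher number from compound 1 to compound 4 (0.60 log units; beyond the scatter), the first step that can be read across a single change. As far as these compounds go, the full size of that step stays unknown, since compound 1 is reported only as a limit: the limit of < 2000 nM in this assay, at which 1 of the 4 values shown sits. Compound 4 gives 8000 nM, a real number for the core of compound 1, so further changes on this core can now be read as measured steps.

From the compounds shown here alone, it remains open whether any group at this place would read like hydrogen, or whether an amine or a carboxylic acid there would give a different number. Going by these compounds, it is also open whether going from 3-methoxyphenyl to phenyl would give a similar step on a different core.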